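This account rests on a few compounds, and the source may have more. Where it says the series, first, only, none or still open, it means among the compounds named here.

Compound 1 `Cc1ccc(NC(=O)Nc2cccc(-c3cccc4[nH]nc(N)c34)c2)cc1`: 4450 nM
Compound 2 `Nc1n[nH]c2cccc(-c3cccc(NC(=O)Nc4cccc(F)c4)c3)c12`: 1240 nM
Compound 3 `Nc1n[nH]c2cccc(-c3cccc(NC(=O)Nc4ccc(F)c(F)c4)c3)c12`: 5880 nM

All three share one core and differ only in the group on an amide-type nitrogen, and all were tested in a functional assay on SMMC-7721 cells (Homo sapiens) for inhibition, read by MTT assay, with a stated time of 48 h; on this read-out higher numbers stand for weaker inhibition and lower numbers for stronger inhibition. Compound 3 gives the highest number of the three; its gap to compound 1, a 1.3-fold higher number from compound 1 to compound 3 (0.12 log units; within the scatter), stays within the scatter, whereas the step of a 4.7-fold higher number from compound 2 to compound 3 (0.68 log units; beyond the scatter) goes beyond it. Compound 4 `Nc1n[nH]c2cccc(-c3cccc(NC(=O)Nc4nccs4)c3)c12` carries 1,3-thiazol-2-yl in place of 3,4-difluorophenyl on an amide-type nitrogen. Among the compounds with values here, no measured step exchanges a six-membered carbon ring for a five-membered ring with hetero atoms; the steps of a 3.6-fold lower number from compound 1 to compound 2 (0.55 log units; beyond the scatter) and a 4.7-fold higher number from compound 2 to compound 3 (0.68 log units; beyond the scatter) only rearrange substituents on a phenyl ring, so they give little guidance. The expected step of a 1.5-fold lower number from compound 3 to compound 4 (0.17 log units; within the scatter) is therefore none beyond the scatter, with wide uncertainty. Compound 4 is estimated at 4000 nM, within 1200 nM to 13000 nM.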

Compound 4, half-maximal inhibitory concentration: 550 nM
Compound 4: middle estimate off by 7.3-fold (0.86 log units), on the high side; measured number outside the range, below it.
By their numbers in this assay, from the lowest: compound 4; then compound 2; then compounds 1 and 3 (each within the scatter of the next).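

Swapping a phenyl ring for a five-membered aromatic ring on the amide-type nitrogen changes the result far more than moving substituents around the phenyl did: 1,3-thiazol-2-yl gives an 11-fold lower number from compound 3 to compound 4 (1.03 log units; beyond the scatter), an 8.1-fold lower number from compound 1 to compound 4 (0.91 log units; beyond the scatter) and a 2.3-fold lower number from compound 2 to compound 4 (0.35 log units; beyond the scatter). So compound 4 beats all three phenyl compounds, and the phenyl ring is not needed at this position. Nothing measured here explains the gain.

Going by these compounds, it remains open whether a morpholine ring or a propyl chain on this nitrogen would keep the lower number. On these data alone, it is also open whether a methyl group on the 1,3-thiazol-2-yl ring would keep it.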